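From Chloro to Acetamido on an Aromatic Carbon

The compounds below may be only part of what the source reports. "The series", "measured", "known", "first", "only" and "open" are said of these compounds alone.

Within the data shown here, in a functional assay (aorta) with Oryctolagus cuniculus as the target (a lower number here means tighter binding, a higher number weaker binding), compound 1 `COc1cc(C(C)=O)ccc1OCCCN1CCC(C(c2ccc(F)cc2)c2ccc(F)cc2)CC1` gives 1.59 nM and compound 2 `Fc1ccc(C(c2ccc(F)cc2)C2CCN(CCCOc3ccc(Cl)cc3)CC2)cc1` gives 2 nM, so compound 2 lies within the scatter of the only other measured value. Compound 3 `CC(=O)Nc1ccc(OCCCN2CCC(C(c3ccc(F)cc3)c3ccc(F)cc3)CC2)cc1` differs from compound 2 by acetamido in place of chloro on an aromatic carbon, with acetamido in place of chloro on an aromatic carbon. Among the measured compounds shown here, the one measured step, a 1.3-fold higher number from compound 1 to compound 2 (0.10 log units; within the scatter), altered the same aromatic ring, so no change beyond the scatter is expected in this assay. The estimated step is a 1.3-fold higher number from compound 2 to compound 3 (0.10 log units; within the scatter). For compound 3 the expected value is 2.5 nM, with an estimated range of 0.8 nM to 8 nM.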

Compound 3, dissociation constant: 12.6 nM
The estimate for compound 3 lay 5.0-fold (0.70 log units) below the measured number; measured number outside the range, above it.
By their numbers in this assay, from the lowest: compounds 1 and 2 (each within the scatter of the next); then compound 3.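

Putting acetamido in place of chloro on this aromatic carbon, para to a large group, moved the number beyond the scatter (a 6.3-fold higher number from compound 2 to compound 3 (0.80 log units; beyond the scatter)) in this assay. The 4-acetamidophenyl group also separates from the 4-acetyl-2-methoxyphenyl group (a 7.9-fold higher number from compound 1 to compound 3 (0.90 log units; beyond the scatter)), whereas 4-chlorophenyl had not, so this ring's substituent can change the reading. Nothing available here explains the rise. The compounds shown leave open how a simple amine or a carboxylic acid on this same carbon would read, and whether either would stay with chloro or move with acetamido.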